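From Piperazinyl to Isoxazolylamino at the Shared Core

The source may report more compounds than this note shows. Statements on the series, on what has been measured and on what is new or still open speak of the compounds shown alone.

Among the measured compounds shown here, compound 2 `CCN1CCN(c2nc(Nc3ccc(C(=O)NC4CC(C)(C)N([O])C(C)(C)C4)cc3)ncc2[N+](=O)[O-])CC1` holds the highest of the two numbers so far in a functional assay on HepG2 cells (Homo sapiens) for antiproliferative activity, read by MTT assay, with a stated time of 48 h; a lower number here means a stronger inhibitor, a higher number a weaker inhibitor: in this assay compound 2 gives 56800 nM, while compound 1 `CC1(C)CC(NC(=O)c2ccc(Nc3ncc([N+](=O)[O-])c(NC4CCCC4)n3)cc2)CC(C)(C)N1[O]` gives 28700 nM. For the measured compounds named here, the only step between them, a 2.0-fold higher number from compound 1 to compound 2 (0.30 log units; within the scatter), lies within the scatter, so the two compounds cannot be told apart on these numbers.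

Compound 3 `Cc1cc(Nc2nc(Nc3ccc(C(=O)NC4CC(C)(C)N([O])C(C)(C)C4)cc3)ncc2[N+](=O)[O-])no1` arises from compound 2 by (5-methyl-1,2-oxazol-3-yl)amino in place of 4-ethylpiperazin-1-yl on an aromatic carbon. Going by the values given here, the single measured step bearing on this position is the one from compound 1 to compound 2, which exchanged a different pair of groups at the same carbon and stayed within the scatter. Among the compounds with values here, no measured step covers an amino-linked aromatic ring entering there. On this thin basis the expected step is a 1.3-fold lower number from compound 2 to compound 3 (0.10 log units; within the scatter), with no change beyond the scatter anticipated. Compound 3 is therefore estimated at 45000 nM, with a range from 15000 nM to 150000 nM.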

Compound 3, half-maximal inhibitory concentration: 7360 nM
Compound 3: middle estimate off by 6.1-fold (0.79 log units), on the high side; measured number below the stated range.
By their numbers in this assay, from the lowest: compound 3; then compounds 1 and 2 (each within the scatter of the next).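

At the aromatic carbon ortho to a nitro group, where the earlier exchange stayed within the scatter, a group now shifts the result in this assay: (5-methyl-1,2-oxazol-3-yl)amino in place of 4-ethylpiperazin-1-yl gives a 7.7-fold lower number from compound 2 to compound 3 (0.89 log units; beyond the scatter) and sets compound 3 apart. With the linking nitrogen kept, 5-methyl-1,2-oxazol-3-yl in place of cyclopentyl still gives a 3.9-fold lower number from compound 1 to compound 3 (0.59 log units; beyond the scatter), so the amino link alone does not account for the separation in these numbers. Nothing available here explains the size of either step.

On these data alone, it remains open whether a phenylamino group or a (1,2-oxazol-3-yl)amino group without the methyl would match compound 3. Also open, as far as these compounds go, is whether the step would persist with a nitrile in place of the nitro group.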